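Swapping Amino for Dimethylamino on Two Cores

This account rests on a few compounds, and the source may have more. Where it says the series, first, only, none or still open, it means among the compounds named here.

Measured so far:
compound 1 `CN(C)C(=S)N/N=C/c1cc2cccnc2s1`: 13400 nM
compound 2 `NC(=S)N/N=C/c1cc2cccnc2s1`: > 100000 nM
compound 3 `NC(=S)N/N=C/c1nc2ccccc2s1`: > 100000 nM

All three were tested in a functional assay on HT-29 cells (Homo sapiens) for antiproliferative activity, read by sulforhodamine B assay, with a stated time of 72 h; on this read-out higher numbers stand for weaker inhibition and lower numbers for stronger inhibition. Compound 2 gives > 100000 nM, which is a limit of the assay rather than a number. Compound 3 gives > 100000 nM, again only a limit. Compound 1 gives 13400 nM, a real number. The change from compound 2 to compound 1 is dimethylamino in place of amino on a thiocarbonyl carbon and it produced an at least 7.4-fold lower number from compound 2 to compound 1 (0.87 log units; beyond the scatter); because the starting value sits at the limit of > 100000 nM in this assay, at which 2 of the 3 values shown sit, the true step could be larger than shown. Compound 2 and compound 3 have the same atoms joined differently; the difference between the two cores is not broken down here.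

Compound 4 `CN(C)C(=S)N/N=C/c1nc2ccccc2s1` has not yet been measured. It differs from compound 3 by dimethylamino in place of amino on a thiocarbonyl carbon, the same change as from compound 2 to compound 1, at a place described in identical words. Compound 4 is expected to land near 30000 nM, estimated between 8000 nM and 120000 nM. That expectation means a step of roughly an at least 3.3-fold lower number from compound 3 to compound 4 (0.52 log units; beyond the scatter). It rests on carrying over an at least 7.4-fold lower number from compound 2 to compound 1 (0.87 log units; beyond the scatter) to a core whose starting point is itself only a limit, so the range is wide and a limit remains possible.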

Compound 4, half-maximal inhibitory concentration: 250 nM
For compound 4 the middle estimate is 120-fold (2.08 log units) above the measured one; the whole stated range lies above it.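

In this assay, dimethylamino in place of amino on a thiocarbonyl carbon lowered the number on the second core as well, giving an at least 400-fold lower number from compound 3 to compound 4 (2.60 log units; beyond the scatter), so in these two pairs the change carries over in the same direction. This does not show that it carries over with the same size, and two pairs give no promise about any other core, so the two steps can only be set side by side: the same change on two cores in this assay, an at least 7.4-fold lower number (0.87 log units; beyond the scatter) from compound 2 to compound 1 and an at least 400-fold lower number (2.60 log units; beyond the scatter) from compound 3 to compound 4; the limit leaves it open whether they differ Each step starts from a limit rather than a number, so neither gives the true size of the change: the limit of > 100000 nM in this assay, at which 2 of the 4 values shown sit.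

The compounds shown leave open whether a smaller group such as methylamino, or a larger one such as diethylamino or a piperidine ring, would lower the number on either core as dimethylamino does. They also leave open whether the change would still work with a carbonyl in place of the thiocarbonyl.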